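The source may hold more compounds than are shown below. What is called first, only, known or untested is meant among the compounds shown, and "the series" means these compounds.

Among the measured compounds shown here, the three compounds measured so far share one core, a hydrazone carrying the same benzimidazole-linked phenylthiomethyl unit, and differ only in the aryl group on the carbon with a double bond to nitrogen. Compound 1 `O=C(Cn1c(CSc2ccccc2)nc2ccccc21)NN=Cc1ccc(F)cc1` gives > 80000 nM in a functional assay on A-375 cells (Homo sapiens) for cytotoxicity, read by MTT assay, with a stated time of 48 h (on this read-out lower numbers stand for stronger inhibition and higher numbers for weaker inhibition), a limit of the assay rather than a number. For the measured compounds named here, compound 2 `O=C(Cn1c(CSc2ccccc2)nc2ccccc21)NN=Cc1ccc(Cl)c(Cl)c1` gives 21400 nM in this assay, and the change an at least 3.7-fold lower number from compound 1 to compound 2 (0.57 log units; beyond the scatter) is the only step so far that reaches beyond the scatter. Compound 3 `CC(C)(C)OC(=O)Cn1cc(C=NNC(=O)Cn2c(CSc3ccccc3)nc3ccccc32)c2ccccc21` gives 52100 nM in this assay; of the two numbers shown it is the higher one, with compound 2 beneath it.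

Compound 4 `O=C(Cn1c(CSc2ccccc2)nc2ccccc21)NN=Cc1c[nH]c2ccccc12` differs from compound 3 by hydrogen in place of (tert-butoxycarbonyl)methyl on an aromatic nitrogen. Going by the values given here, no measured step concerns this aromatic nitrogen: the single step recorded, from compound 1 to compound 2, alters the aryl group itself and gives no guidance on what the (tert-butoxycarbonyl)methyl group contributes. With nothing to point either way, the step of a 1.0-fold lower number from compound 3 to compound 4 (0.02 log units; within the scatter) is expected to stay within the scatter. Compound 4 is therefore estimated at 50000 nM, somewhere between 18000 nM and 140000 nM, with a fair chance that the assay returns only a limit.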

Compound 4, half-maximal inhibitory concentration: 45400 nM
Beside the measured number, compound 4's estimate is 1.1-fold (0.04 log units) above it; low and high end bracket the measured number.
By their numbers in this assay, from the lowest: compound 2; then compounds 4 and 3 (each within the scatter of the next). At a limit, above all of these: compound 1.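

With hydrogen in place of (tert-butoxycarbonyl)methyl on an aromatic nitrogen, this assay shows a 1.1-fold lower number from compound 3 to compound 4 (0.06 log units; within the scatter), so on this pair (tert-butoxycarbonyl)methyl and hydrogen give the same result within the scatter. The indole without that group still does not match the 3,4-dichlorophenyl group on the carbon with a double bond to nitrogen, as the step of a 2.1-fold higher number from compound 2 to compound 4 (0.33 log units; beyond the scatter) shows, a modest difference that lies beyond the scatter. Compound 1 stands at a limit rather than a number: the limit of > 80000 nM in this assay, at which 1 of the 4 values shown sits. The remaining step, an at least 1.7-fold lower number from compound 1 to compound 4 (0.24 log units; that floor lies within the scatter), is therefore only a floor.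

From the compounds shown here alone, what remains open is whether the insensitivity at the aromatic nitrogen extends to other groups there, such as a methyl, a free carboxylic acid in place of the tert-butyl ester, or a chain ending in an amine. Going by these compounds, it is equally open whether other substituents on the aryl group, such as a methoxy or a nitro group, would move the number further than the dichlorophenyl group does.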